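The compounds below may be only part of what the source reports. "The series", "measured", "known", "first", "only" and "open" are said of these compounds alone.

Of the compounds shown here, three built on one shared core have been tested in a functional assay on PANC-1 cells (Homo sapiens) for inhibition, read by MTT assay, with a stated time of 24 h; a lower number here means a stronger inhibitor, a higher number a weaker inhibitor. Compound 1 `Cc1ccccc1-n1cc(CN2C(=O)C[C@@H]3CC[C@@]2(C)C3(C)C)nn1` gives 250 nM. Compound 2 `COc1ccc(-n2cc(CN3C(=O)C[C@@H]4CC[C@@]3(C)C4(C)C)nn2)cc1`, carrying a 4-methoxyphenyl in place of the 2-methylphenyl, gives 330 nM. Compound 3 `CC1(C)[C@H]2CC[C@]1(C)N(Cc1cn(-c3ccccc3Br)nn1)C(=O)C2`, carrying a 2-bromophenyl, gives 280 nM. Compound 1 has the lowest of the three numbers, but the steps of a 1.3-fold higher number from compound 1 to compound 2 (0.12 log units; within the scatter) and a 1.1-fold higher number from compound 1 to compound 3 (0.05 log units; within the scatter) both lie within the scatter, so the three cannot be told apart.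

Compound 4 `CC1(C)[C@H]2CC[C@]1(C)N(Cc1cn(-c3cccc(Br)c3)nn1)C(=O)C2` has not yet been measured. Its change from compound 1 is 3-bromophenyl in place of 2-methylphenyl on an aromatic nitrogen. Within the data shown here, two measured steps bear on this: the exchange of bromo for methyl on an aromatic carbon, a 1.1-fold higher number from compound 1 to compound 3 (0.05 log units; within the scatter), and the exchange of the whole phenyl group, a 1.3-fold higher number from compound 1 to compound 2 (0.12 log units; within the scatter). Among the measured compounds shown here, neither reached beyond the scatter, and no step so far has. For compound 4 no step beyond the scatter is therefore expected. The expected step is a 1.1-fold higher number from compound 1 to compound 4 (0.05 log units; within the scatter). Compound 4 is estimated to give 280 nM, with a range from 150 nM to 550 nM.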

Compound 4, half-maximal inhibitory concentration: 90 nM
The estimate for compound 4 lay 3.1-fold (0.49 log units) above the measured number; the measured number lies below the stated range.
By their numbers in this assay, from the lowest: compound 4; then compounds 1, 3 and 2 (each within the scatter of the next).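

In this assay the group on the aromatic nitrogen can clearly move the number: with the 3-bromophenyl there is a 2.8-fold lower number from compound 1 to compound 4 (0.44 log units; beyond the scatter) and also a 3.7-fold lower number from compound 2 to compound 4 (0.56 log units; beyond the scatter), whereas the steps among compounds 1, 2 and 3 all stayed within the scatter. Bromine alone does not account for this, since moving it from the 2-bromophenyl to the 3-bromophenyl gives a 3.1-fold lower number from compound 3 to compound 4 (0.49 log units; beyond the scatter) on an otherwise identical structure, so where the bromine sits on the phenyl ring matters, and compound 4 is the strongest inhibitor of the four. No measurement available here explains why this placement of bromine gives the lower number.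

The compounds shown leave open whether bromine itself is needed, which a 3-chlorophenyl or 3-methylphenyl would test. On these data alone, how a 4-bromophenyl compares also remains open.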